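Bromoalkyl chain shortening: compound 2 to compound 4

The source may report more compounds than this note shows. Statements on the series, on what has been measured and on what is new or still open speak of the compounds shown alone.

Measured so far in a functional assay on U-937 cells (Homo sapiens) for cytotoxicity, read by MTT assay, with a stated time of 24 h; a higher number here means a weaker inhibitor, a lower number a stronger inhibitor:
- compound 1 `BrCCCOc1c(Br)cc(Br)cc1Oc1ccc(Br)cc1Br` gives 30.3 ug/mL
- compound 2 `BrCCCCCCOc1c(Br)cc(Br)cc1Oc1ccc(Br)cc1Br` gives 33.8 ug/mL
- compound 3 `CC(C)(C)OC(=O)N1CCN(CCCCCOc2c(Br)cc(Br)cc2Oc2ccc(Br)cc2Br)CC1` gives 35.5 ug/mL

Compound 2 lies within the scatter of both compound 1 and compound 3. The next structure, compound 4 `BrCCCCCOc1c(Br)cc(Br)cc1Oc1ccc(Br)cc1Br`, differs from compound 2 as follows: bromo in place of bromomethyl on a saturated chain carbon, five bonds along the chain from an oxygen on an aromatic ring. Among the compounds with values here, the one measured step that bears on this change is a 1.1-fold higher number from compound 1 to compound 2 (0.05 log units; within the scatter). On that evidence, no step beyond the scatter is expected in this assay. The expected step is a 1.1-fold lower number from compound 2 to compound 4 (0.02 log units; within the scatter). For compound 4 the estimated value is 32 ug/mL, with an expected range of 22 ug/mL to 45 ug/mL.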

Compound 4, half-maximal inhibitory concentration: 29.5 ug/mL
Compound 4: the middle estimate sits 1.1-fold (0.04 log units) above what was measured; measured number inside the range.
By their numbers in this assay, from the lowest: compounds 4, 1, 2 and 3 (each within the scatter of the next).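

Within the bromoalkyl chains on the shared core, this assay gives a 1.1-fold lower number from compound 2 to compound 4 (0.06 log units; within the scatter) and a 1.0-fold lower number from compound 1 to compound 4 (0.01 log units; within the scatter). Both steps lie within the scatter, so compounds 1, 2 and 4 show no dependence on chain length at this position, whether the change is read from compound 2 or from compound 1. No evidence on the cause of this flat result is available. Still open, from the compounds shown here alone, is whether a free amine or a carboxylic acid in place of the terminal bromo would give a step beyond the scatter. Going by these compounds, a longer chain than that of compound 2 also remains open.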